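A few compounds are considered here, and "the series" means these few. Any claim that something is new, unique, unknown or untested is made for them only; others in the source may bear on it.

Three compounds of this series have been checked for cytotoxicity in an ADME assay on PC-3 cells (Homo sapiens) for cytotoxicity, read by WST assay, tested at 100 uM; on this read-out higher numbers stand for more inhibition at the one concentration tested (going by the name of the read-out) and lower numbers for less inhibition. Compound 1 `O=C(Nc1cccc(Oc2ccccn2)c1)C1CCCN(C(=O)c2cc(C(F)(F)F)cc(C(F)(F)F)c2)C1` gives 0% there. Compound 2 `O=C(Nc1cccc(Cc2ccccc2)c1)C1CCCN(C(=O)c2cccc(-c3ccco3)c2)C1` gives 0%, level with compound 1 at the digits shown, and together these two are the lowest of the three numbers. Compound 3 `CS(=O)(=O)c1cccc(C(=O)N2CCCC(C(=O)Nc3ccc(Cl)cc3)C2)c1` gives 2%, a number that lies within the scatter of compound 1. No two of these compounds differ in one place only, so no single step has been measured.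

Compound 4 `O=C(Nc1cccc(Oc2nccc(C(F)(F)F)c2Cl)c1)C1CCCN(C(=O)c2cc(C(F)(F)F)cc(C(F)(F)F)c2)C1` is still to be measured in this assay. It differs from compound 1 in one place: 3-chloro-4-(trifluoromethyl)pyridin-2-yl in place of pyridin-2-yl on an oxygen on an aromatic ring. Compound 1 gives 0%, and compounds 2 and 3 sit within the scatter of it, so nothing in the numbers points to a step beyond the scatter. The expected step is a number 3 percentage points higher from compound 1 to compound 4 (within the scatter), none beyond the scatter. Compound 4 is estimated to give 3%, within -8% to 16%.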

Compound 4, a percentage reported as inhibition, at one concentration (the size of the read-out at that concentration, not a potency): 0%
Estimate against measurement, compound 4: 3 percentage points above; low and high end bracket the measured number.
By their numbers in this assay, from the lowest: compounds 1, 2, 4 and 3 (each within the scatter of the next).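

For the compounds shown here, the first single step falls at this position: 3-chloro-4-(trifluoromethyl)pyridin-2-yl in place of pyridin-2-yl on an oxygen on an aromatic ring gives no change at the digits printed from compound 1 to compound 4 (within the scatter) in this assay. This position therefore takes the larger substituted group without a step beyond the scatter at the one concentration tested. No measurement on hand bears on why the number stays level.

Open, going by these compounds, is whether an amine or a carboxylic acid on the pyridin-2-yl would also stay within the scatter in this assay. The same holds for a longer chain in place of that ring on the oxygen.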